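This account rests on a few compounds, and the source may have more. Where it says the series, first, only, none or still open, it means among the compounds named here.

Of the compounds shown here, three built on one shared core have been tested in an ADME assay on MT4 cells (Homo sapiens) for cytotoxicity, read by MTT assay; on this read-out lower numbers stand for higher toxicity in this test and higher numbers for lower toxicity in this test. Compound 2 `N#Cc1ccc(Nc2nccc(NC3CCCCC3)n2)cc1` gives 7330 nM and stands highest of the three numbers. Compound 3 `Cc1cnc(Nc2ccc(C#N)cc2)nc1NC1CCCCC1`, which carries a methyl in place of a hydrogen on an aromatic carbon of that core, gives 1300 nM, and the step of a 5.6-fold lower number from compound 2 to compound 3 (0.75 log units; beyond the scatter) lies beyond the scatter. Compound 1 `Cc1cc(OC2CCCC2)nc(Nc2ccc(C#N)cc2)n1`, which carries both a methyl and a cyclopentyloxy group, gives 1050 nM.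

Compound 4 `N#Cc1ccc(Nc2nccc(OC3CCCC3)n2)cc1` differs from compound 2 in one place: cyclopentyloxy in place of cyclohexylamino on an aromatic carbon. Within the data shown here, no measured step covers this change on its own. Among the measured compounds shown here, the single measured step, from compound 2 to compound 3, concerns a methyl and does not speak to it. Compound 1 and compound 3 do differ in this way, but they also differ elsewhere in the core, so no clean step can be read from them; their two values lie close together, within the usual scatter, which gives no sign that this exchange moves the number much. For compound 4 the step of a 1.5-fold lower number from compound 2 to compound 4 (0.17 log units; within the scatter) is therefore expected to be small, with wide uncertainty. The estimated value for compound 4 in this assay is 5000 nM, in a range from 1500 nM to 15000 nM.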

Compound 4, half-maximal cytotoxic concentration: >= 339000 nM
Compound 4: only a limit was reported; the forecaster's own chance of this, stated with the estimate: 10%; at least 67-fold (1.83 log units) between middle value and limit.
By their numbers in this assay, from the lowest: compounds 1 and 3 (each within the scatter of the next); then compound 2. At a limit, above all of these: compound 4.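

In this assay, among these compounds, cyclopentyloxy in place of cyclohexylamino on this aromatic carbon gives an at least 46-fold higher number from compound 2 to compound 4 (1.66 log units; beyond the scatter), so this one exchange, which no earlier step covered, moves the read-out strongly towards lower toxicity in this test. Compound 4 stands at a limit and not at a measured number, so this step and the next one give only a minimum size: the limit of >= 339000 nM in this assay, at which 1 of the 4 values shown sits. Hydrogen in place of methyl on the cyclopentyloxy core gives an at least 320-fold higher number from compound 1 to compound 4 (2.50 log units; beyond the scatter), which shows that the methyl does not act by the same amount on every core: the same change on two cores in this assay, a 5.6-fold lower number (0.75 log units; beyond the scatter) from compound 2 to compound 3 and an at least 320-fold lower number (2.50 log units; beyond the scatter) from compound 4 to compound 1, at least 57-fold (1.75 log units) apart, beyond the scatter of two such steps.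

The exchange alters the ring and the atom linking it to the core together, leaving open which of the two carries the step; a cyclopentylamino or a cyclohexyloxy group at this position would pull them apart. The compounds shown also leave open whether other groups on this carbon, such as a longer open chain ending in an amine, would behave like cyclopentyloxy or like cyclohexylamino.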